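Tert-butyl for isopropoxy on the pyrimidine of compound 2

This account rests on a few compounds, and the source may have more. Where it says the series, first, only, none or still open, it means among the compounds named here.

Compound 1, `CCOc1ncc(-c2nc(C(F)(F)F)sc2N2CCN(C(=O)Cn3ccc4cnccc43)[C@H](C)C2)cn1`: 25 nM
Compound 2, `Cc1nc(C)n(CC(=O)N2CCN(c3sc(C(F)(F)F)nc3-c3cnc(OC(C)C)nc3)C[C@H]2C)n1`: 216 nM

In an assay on blood for inhibition of C-X-C chemokine receptor type 3 (Homo sapiens), with a stated time of 30 min (on this read-out higher numbers stand for weaker inhibition and lower numbers for stronger inhibition), compound 1 gives 25 nM. Compound 2 has the highest number of the two; in this assay compound 2 gives 216 nM, and the gap to compound 1 is beyond the scatter. The two compounds differ in more than one place, so their values only show where each stands, not what any single change does.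

Compound 3, `Cc1nc(C)n(CC(=O)N2CCN(c3sc(C(F)(F)F)nc3-c3cnc(C(C)(C)C)nc3)C[C@H]2C)n1`, is not yet measured. It differs from compound 2 in one place: tert-butyl in place of isopropoxy on an aromatic carbon. Within the data shown here, no measured pair shows this exchange, so there is no step to lean on. The change is expected to leave the number near that of compound 2, perhaps somewhat weaker. For compound 3 the estimated value is 320 nM, with a range of 80 nM to 1300 nM, a step of a 1.5-fold higher number from compound 2 to compound 3 (0.17 log units; within the scatter).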

Compound 3, half-maximal inhibitory concentration: 1160 nM
Beside the measured number, compound 3's estimate is 3.6-fold (0.56 log units) below it, within the range that was stated.
By their numbers in this assay, from the lowest: compound 1; then compound 2; then compound 3.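

Read in this assay there is a 5.4-fold higher number from compound 2 to compound 3 (0.73 log units; beyond the scatter) when tert-butyl takes the place of isopropoxy on the aromatic carbon between two ring nitrogen atoms. Among these compounds, this is the first change that can be read on its own, and it shows that this position does not treat two groups of equal heavy-atom count alike: the isopropoxy group holds an oxygen and a hydrogen-bond acceptor, while the tert-butyl group holds carbon only. No measurement at hand accounts for the size of this step.

Whether the oxygen itself matters stays open, since the shown exchange alters the atom count and the branching together; an isobutyl chain or a methylamine at this position would separate the two. As far as these compounds go, how the same exchange behaves on compound 1 also remains unknown.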